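Cytotoxicity at the assay limit across the amide series

The compounds below may be only part of what the source reports. "The series", "measured", "known", "first", "only" and "open" are said of these compounds alone.

The compounds share one core and vary the amide substituent. Compound 1 `CCCCCN1C(=O)C/C(=C\c2cccc(C(=O)Nc3ccc(C)cc3)c2)C1=O`, compound 2 `O=C(Nc1ccccc1)c1cccc(/C=C2\CC(=O)N(c3ccccc3)C2=O)c1` and compound 3 `Cc1ccc(N2C(=O)C/C(=C\c3cccc(C(=O)Nc4cccc(F)c4)c3)C2=O)cc1` have all been run in an ADME assay on NCM460 cells (Homo sapiens) for cytotoxicity, read by MTT assay, with a stated time of 72 h; on this read-out lower numbers stand for stronger inhibition and higher numbers for weaker inhibition. In this assay compound 1 sits at a limit of the assay, > 100000 nM. Compound 2 likewise returns only a limit, > 100000 nM. Compound 3 also stands at a limit, > 100000 nM. Compound 2 is therefore not distinguished from the others on the numbers shown, as the limit of > 100000 nM in this assay, at which 3 of the 3 values shown sit, states for all three values.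

Compound 4 `Cc1ccc(NC(=O)c2cccc(/C=C3\CC(=O)N(c4ccccc4)C3=O)c2)cc1C` carries the change (3,4-dimethylphenyl in place of phenyl on an amide-type nitrogen). Among the measured compounds shown here, with no measured step available, no movement beyond the scatter is expected in this assay, and the expected step from compound 2 to compound 4 is a step that the limit leaves unreadable from compound 2 to compound 4. Compound 4 is estimated at 150000 nM, within 50000 nM to 500000 nM.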

Compound 4, half-maximal inhibitory concentration: > 100000 nM
Compound 4: a limit, no number; the forecaster's own chance of this, stated with the estimate: 85%; the middle value does not contradict the limit.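

The step from compound 2 to compound 4 cannot be read in this assay because both compounds stand at a limit: the limit of > 100000 nM in this assay, at which 4 of the 4 values shown sit.

In this assay the compounds shown leave open whether any change on the shared core gives a measurable value.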